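Factor X series: pyridinylamino tail on two sulfonyl cores

This account rests on a few compounds, and the source may have more. Where it says the series, first, only, none or still open, it means among the compounds named here.

Measured compounds:
- compound 1, `O=C1[C@@H](NS(=O)(=O)c2cc3ccnc(Cl)c3s2)CCN1CCNc1ccncc1`: 23%
- compound 2, `O=C1[C@@H](NS(=O)(=O)c2cc3cccnc3s2)CCN1Cc1cc2c[nH]ccc-2n1`: 18%
- compound 3, `O=C1[C@@H](NS(=O)(=O)c2cc3ccnc(Cl)c3s2)CCN1Cc1cc2c[nH]ccc-2n1`: 25%

All three were run in an assay on isolated protein for inhibition of coagulation factor X (Oryctolagus cuniculus), tested at 1 uM; a higher number here means more inhibition at the concentration tested (going by the name of the read-out), a lower number less inhibition. In this assay compound 3 gives 25% and compound 1 gives 23%, and the two differ only in the group on the lactam side chain: a group of 8 heavy atoms (6 carbon, 2 nitrogen; one six-membered aromatic ring with 1 hetero atom) in place of a group of 9 heavy atoms (7 carbon, 2 nitrogen; one five-membered aromatic ring with 1 hetero atom, one six-membered aromatic ring with 1 hetero atom), on a saturated chain carbon bound to an amide-type nitrogen in a ring. The step is a number 2 percentage points lower from compound 3 to compound 1 (within the scatter). Compound 2 shares its side chain with compound 3 but carries a different sulfonyl core: a group of 9 heavy atoms (7 carbon, 1 nitrogen, 1 sulfur; one five-membered aromatic ring with 1 hetero atom, one six-membered aromatic ring with 1 hetero atom) in place of a group of 10 heavy atoms (7 carbon, 1 nitrogen, 1 sulfur, 1 chlorine; one five-membered aromatic ring with 1 hetero atom, one six-membered aromatic ring with 1 hetero atom), on a sulfonyl sulfur. Between these two the step is a number 7 percentage points higher from compound 2 to compound 3 (within the scatter). In this assay compound 2 gives 18%, and none of the three measured numbers stands apart from the others beyond the scatter.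

Compound 4, `O=C1[C@@H](NS(=O)(=O)c2cc3cccnc3s2)CCN1CCNc1ccncc1`, is not yet measured. It differs from compound 2 in the same way that compound 1 differs from compound 3: a group of 8 heavy atoms (6 carbon, 2 nitrogen; one six-membered aromatic ring with 1 hetero atom) in place of a group of 9 heavy atoms (7 carbon, 2 nitrogen; one five-membered aromatic ring with 1 hetero atom, one six-membered aromatic ring with 1 hetero atom), on a saturated chain carbon bound to an amide-type nitrogen in a ring. The place of the change is the same in words for both pairs, so this is taken as the same change on the core of compound 2 rather than on the core of compound 3. Because a number 2 percentage points lower from compound 3 to compound 1 (within the scatter) was flat, the step expected here is a number 2 percentage points lower from compound 2 to compound 4 (within the scatter), i.e. also flat. The estimate for compound 4 in this assay is 16%, with a range from 5% to 28%, resting on the value of compound 2, 18%, and on the near-zero step seen from compound 3 to compound 1. Among the measured compounds shown here, only two compounds carry each change, so nothing wider is claimed.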

Compound 4, a percentage reported as inhibition, at one concentration (the size of the read-out at that concentration, not a potency): 23%
Beside the measured number, compound 4's estimate is 7 percentage points below it; the measured number falls inside the stated range.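

In this assay, putting ((pyridin-4-yl)amino)methyl on the saturated chain carbon bound to the ring amide-type nitrogen gives a number 5 percentage points higher from compound 2 to compound 4 (within the scatter), so on this core too the change leaves the number within the scatter. Set beside the same change on the other core, the new step shows no difference that can be told from the scatter: the same change on two cores in this assay, a number 2 percentage points lower (within the scatter) from compound 3 to compound 1 and a number 5 percentage points higher (within the scatter) from compound 2 to compound 4, 7 percentage points apart, within the scatter of two such steps This shows that, for these two pairs, the change carries from one core to the other without a step beyond the scatter on either, but it does not show that the change is without effect in general, that the two steps are truly the same, or that it would behave this way on any third core, and a single-concentration read-out gives no potency.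

Still open, as far as these compounds go, is whether any change at this place moves the number beyond the scatter, for instance a longer chain in the tail, or a primary amine or a carboxylic acid in place of the pyridine ring. Also open, from the compounds shown here alone, is whether a core with fluorine or a methoxy group in place of the chlorine would give the same flat picture.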